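Working notes: from compound 1 to compound 4

The source may report more compounds than this note shows. Statements on the series, on what has been measured and on what is new or still open speak of the compounds shown alone.

Measured so far in a functional assay on PC-9 cells (Homo sapiens) for inhibition, read by MTT assay, with a stated time of 48 h, tested at 10 uM; a lower number here means less inhibition, a higher number more inhibition at the concentration tested (going by the name of the read-out):
compound 1 `COc1cc(NC(=O)Nc2cc(Nc3ccc(OC)c(C)c3)ncn2)cc(OC)c1` gives 62%
compound 2 `COc1cc(Nc2cc(NC(=O)Nc3c(Cl)cccc3Cl)ncn2)cc(OC)c1` gives 90%
compound 3 `CC(C)(C)c1ccc(Nc2cc(NC(=O)Nc3c(Cl)cccc3Cl)ncn2)cc1` gives 41.5%

Compound 1 stands second highest of the three numbers in this assay; compound 3 lies lower by a gap beyond the scatter, and compound 2 lies higher by a gap beyond the scatter. Compound 4 `COc1cc(NC(=O)Nc2cc(Nc3cc(I)ccc3OC)ncn2)cc(OC)c1` differs from compound 1 in one place: 5-iodo-2-methoxyphenyl in place of 4-methoxy-3-methylphenyl on a nitrogen on an aromatic ring. Among the compounds with values here, compounds 2 and 3 alter other parts of the structure, so the measured numbers contain no step that mirrors this exchange, and nothing among them points in a direction for it. In this assay the step expected from this change, a number 2 percentage points lower from compound 1 to compound 4 (within the scatter), is none beyond the scatter. Compound 4 is therefore estimated at 60%, within a range of 35% to 85%.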

Compound 4, a percentage reported as inhibition, at one concentration (the size of the read-out at that concentration, not a potency): 91%
For compound 4 the middle estimate is 31 percentage points below the measured one; measured number above the stated range.
By their numbers in this assay, from the lowest: compound 3; then compound 1; then compounds 2 and 4 (each within the scatter of the next).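

In this assay, 5-iodo-2-methoxyphenyl in place of 4-methoxy-3-methylphenyl on a nitrogen on an aromatic ring gives a number 29 percentage points higher from compound 1 to compound 4 (beyond the scatter), so the number responds to this exchange when the rest of compound 1 stays fixed. This is the only step among the compounds shown that isolates this position. No measurement at hand accounts for the step.

On these data alone, the exchange alters several features of the ring at once, and the share of the iodine in the step remains open. Also open, as far as these compounds go, is how a bromine or a dimethylamino group in place of that iodine would read.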